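From 3-Fluorophenyl to 4-Fluorophenyl: A Small Expected Step

This account rests on a few compounds, and the source may have more. Where it says the series, first, only, none or still open, it means among the compounds named here.

Compound 1 `COc1ccc(-c2nc3cccc(-c4cc(OC)c(OC)c(OC)c4)c3o2)cc1F`: 1800 nM
Compound 2 `COc1cc(-c2cccc3nc(-c4cccc(F)c4)oc23)cc(OC)c1OC`: 2600 nM

Within the data shown here, in a functional assay on A549 cells (Homo sapiens) for antiproliferative activity, read by MTT assay, with a stated time of 48 h (on this read-out higher numbers stand for weaker inhibition and lower numbers for stronger inhibition), compound 2 gives 2600 nM, which lies within the scatter of compound 1, the only other compound measured. Compound 3 `COc1cc(-c2cccc3nc(-c4ccc(F)cc4)oc23)cc(OC)c1OC` has not yet been measured. It differs from compound 2 in one place: 4-fluorophenyl in place of 3-fluorophenyl on an aromatic carbon. The fluorine-bearing group therefore changes from 3-fluorophenyl to 4-fluorophenyl, while the rest of the structure stays the same. Among the measured compounds shown here, only one measured step bears on this change, a 1.4-fold higher number from compound 1 to compound 2 (0.16 log units; within the scatter), which places hydrogen in place of methoxy on an aromatic carbon. It is a different change, and the data contain no direct comparison of the two fluorophenyl groups. With that single small step as the guide, no shift beyond the scatter is expected in this assay. For compound 3 the expected step is a 1.1-fold lower number from compound 2 to compound 3 (0.05 log units; within the scatter). Compound 3 is estimated at 2300 nM, with an expected range from 1000 nM to 5200 nM.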

Compound 3, half-maximal inhibitory concentration: 8700 nM
Beside the measured number, compound 3's estimate is 3.8-fold (0.58 log units) below it, outside the stated range (above it).
By their numbers in this assay, from the lowest: compounds 1 and 2 (each within the scatter of the next); then compound 3.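

In this assay, moving the fluorine on the phenyl group attached to the five-membered aromatic ring has a measurable effect: the change from 3-fluorophenyl to 4-fluorophenyl gives a 3.3-fold higher number from compound 2 to compound 3 (0.52 log units; beyond the scatter), even though the two groups have the same atoms. Among these compounds, the earlier pair showed only a step within the scatter, so this is the first sign that this position responds to a change in the aryl group. The 3-fluoro-4-methoxyphenyl group of compound 1 gives way to 4-fluorophenyl with a similar result, a 4.8-fold higher number from compound 1 to compound 3 (0.68 log units; beyond the scatter), which leaves compound 3 apart from the other two compounds.

Going by these compounds, it remains open whether an amine or a carboxylic acid in place of the fluorine would keep or lose activity in this assay. Nothing measured here explains why the fluorine's location changes the number.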